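Swapping Acetyl for Cyano on a Vinyl Sulfone Core

The compounds below may be only part of what the source reports. "The series", "measured", "known", "first", "only" and "open" are said of these compounds alone.

Of the compounds shown here, three sharing the same core have been tested in a functional assay on KM12 cells (Homo sapiens) for inhibition, read by sulforhodamine B assay, with a stated time of 48 h; on this read-out lower numbers stand for stronger inhibition of growth and higher numbers for weaker inhibition of growth. Compound 1 `CCOC(=O)C(=Cc1c(-c2ccccc2)[nH]c2ccccc12)C(=O)OCC` gives 3500 nM in this assay. Compound 2 `CC(=O)/C(=C\c1c(-c2ccccc2)[nH]c2ccccc12)S(=O)(=O)c1ccccc1` gives 1000 nM in this assay, the lowest number of the three. Compound 3 `COc1ccc2[nH]c(-c3ccccc3)c(C=C(C#N)C#N)c2c1` gives 3500 nM in this assay. Compound 1 and compound 3 each stand at a higher number than compound 2, and both gaps lie beyond the usual scatter of repeat measurements, so compound 2 is the most potent growth inhibitor among the measured set.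

Compound 4 `N#C/C(=C\c1c(-c2ccccc2)[nH]c2ccccc12)S(=O)(=O)c1ccccc1` has not yet been measured. It differs from compound 2 in one place: cyano in place of acetyl on a double-bonded chain carbon bound to a double-bonded chain carbon and a sulfonyl sulfur. Among the measured compounds shown here, no pair of measured compounds differs in exactly this way, so there is no direct precedent for the size of the step. The expectation is a modest change, most likely a somewhat higher number than compound 2, though possibly within the scatter. For compound 4 the estimated value in this assay is 1600 nM, with a range from 500 nM to 5000 nM. This estimate corresponds to an expected step of a 1.6-fold higher number from compound 2 to compound 4 (0.20 log units; within the scatter).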

Compound 4, concentration for 50% growth inhibition: 652 nM
Estimate against measurement, compound 4: 2.5-fold (0.39 log units) above, and the stated range covers the measured number.
By their numbers in this assay, from the lowest: compounds 4 and 2 (each within the scatter of the next); then compounds 1 and 3 (each within the scatter of the next).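

In this assay, cyano in place of acetyl on a double-bonded chain carbon bound to a double-bonded chain carbon and a sulfonyl sulfur gives a 1.5-fold lower number from compound 2 to compound 4 (0.19 log units; within the scatter). Among the compounds shown here, this is the first one-place comparison in the set, and it shows that this position accepts a cyano of 2 heavy atoms as readily as an acetyl of 3 heavy atoms, with no measurable difference in growth inhibition; each group carries 1 hydrogen-bond acceptor and no net charge. Nothing shown explains why the two groups give such similar numbers.

Going by these compounds, whether an amine, a carboxylic acid or a longer acyl chain such as butanoyl would be accepted at this position remains open. Compound 1 and compound 3 each differ from compound 4 in more than one place, so the contribution of the sulfonyl group also remains unresolved.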